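Chloro for methyl on the amide aryl ring of compound 3

This account rests on a few compounds, and the source may have more. Where it says the series, first, only, none or still open, it means among the compounds named here.

Measured so far in a functional assay on K562 cells (Homo sapiens) for cytotoxicity, read by WST assay, with a stated time of 72 h; a lower number here means a stronger inhibitor, a higher number a weaker inhibitor:
compound 1 `COc1cc2c(Nc3nc4ccc(C(=O)Nc5c(C)cccc5C)cc4s3)ncnc2cc1OCCCN1CCCCC1` gives 13700 nM;
compound 2 `CCN(CC)CCCOc1cc2ncnc(Nc3nc4ccc(C(=O)Nc5c(C)cccc5Cl)cc4s3)c2cc1OC` gives 9600 nM;
compound 3 `COc1cc2c(Nc3nc4ccc(C(=O)Nc5c(C)cccc5C)cc4s3)ncnc2cc1OCCCN1CCC(C)CC1` gives 15800 nM.

Compound 3 carries the highest of the three numbers, but its gaps to compound 1 and compound 2 are both within the scatter, so the three stand as one. Among the measured compounds shown here, the only single-point step among them, a 1.2-fold higher number from compound 1 to compound 3 (0.06 log units; within the scatter), changes nothing beyond the scatter. Compound 4 `COc1cc2c(Nc3nc4ccc(C(=O)Nc5c(C)cccc5Cl)cc4s3)ncnc2cc1OCCCN1CCC(C)CC1` differs from compound 3 by chloro in place of methyl on an aromatic carbon. For the measured compounds named here, no measured step shows this exchange on its own; compound 2, which carries the same 2-chloro-6-methylphenyl group on a different amine chain, sits within the scatter of compound 3. Compound 4 is therefore expected to give 11000 nM in this assay, between 5000 nM and 25000 nM, a step of a 1.4-fold lower number from compound 3 to compound 4 (0.16 log units; within the scatter).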

Compound 4, half-maximal inhibitory concentration: 8300 nM
For compound 4 the middle estimate is 1.3-fold (0.12 log units) above the measured one; the range from low to high includes it.
By their numbers in this assay, from the lowest: compounds 4, 2, 1 and 3 (each within the scatter of the next).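

In this assay, chloro in place of methyl on an aromatic carbon gives a 1.9-fold lower number from compound 3 to compound 4 (0.28 log units; within the scatter), so this exchange, now seen on its own, stays within the scatter at this position. With the 2-chloro-6-methylphenyl group held fixed, 4-methylpiperidin-1-yl in place of diethylamino gives a 1.2-fold lower number from compound 2 to compound 4 (0.06 log units; within the scatter), also within the scatter, so this change at the end of the chain does not separate the two compounds either. No measurement given here bears on the reason for either step.

The compounds shown leave open whether fluoro or methoxy on that aromatic carbon, or morpholine at the end of the chain, would move the number beyond the scatter.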